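Swapping Chloro for Nitro on a Shared Core

The source may hold more compounds than are shown below. What is called first, only, known or untested is meant among the compounds shown, and "the series" means these compounds.

Of the compounds shown here, two built on the same core have been measured in a functional assay on HeLa cells (Homo sapiens) for cytotoxicity, read by MTT assay, with a stated time of 48 h; on this read-out higher numbers stand for weaker inhibition and lower numbers for stronger inhibition. Compound 1, `O=C1C(O)=C(C(c2ccccc2)c2c(-c3ccccc3)[nH]c3ccccc23)C(=O)c2ccccc21`, gives 18800 nM in this assay. Compound 2, `Cc1[nH]c2ccccc2c1C(C1=C(O)C(=O)c2ccccc2C1=O)c1ccc(Cl)cc1`, gives 8030 nM in this assay. Of these two numbers, compound 2 gives the lower one, and compound 1 sits higher by a gap that goes beyond the usual scatter of repeated measurements, so compound 2 is the stronger inhibitor of the pair.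

Compound 3, `Cc1[nH]c2ccccc2c1C(C1=C(O)C(=O)c2ccccc2C1=O)c1ccc([N+](=O)[O-])cc1`, has not yet been measured. It differs from compound 2 in one place: nitro in place of chloro on an aromatic carbon. The nitro group enters on an aromatic carbon of a six-membered aromatic ring of carbon only, para to a large group, where the chloro group of compound 2 stood. Among the measured compounds shown here, no measured pair shows what this swap does on this core, and compound 1 and compound 2 differ in more than one place, so their two values cannot be read as a guide to it. The expectation for compound 3 is a small step of a 1.3-fold lower number from compound 2 to compound 3 (0.13 log units; within the scatter), most likely within the scatter. Compound 3 is therefore estimated at 6000 nM, with a range from 2500 nM to 20000 nM.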

Compound 3, half-maximal inhibitory concentration: 4570 nM
Compound 3: the middle estimate sits 1.3-fold (0.12 log units) above what was measured, within the range that was stated.
By their numbers in this assay, from the lowest: compounds 3 and 2 (each within the scatter of the next); then compound 1.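

In this assay, the swap of nitro for chloro on an aromatic carbon, para to a large group, gives a 1.8-fold lower number from compound 2 to compound 3 (0.24 log units; within the scatter), so on this read-out the two groups cannot be told apart at this position. Among the compounds shown here, this is the first direct view of the position, which the earlier pair could not give: the 4-chlorophenyl of compound 2 can give way to the 4-nitrophenyl of compound 3, a group of 3 heavy atoms with 2 hydrogen-bond acceptors in place of a single chlorine with none, and the value stays within the usual scatter. Nothing in the data shown accounts for why the two compounds read alike in this cell assay.

For the compounds shown here, with only this one swap at the position, it remains open how much the position tolerates in general, and whether this result would hold for a quite different group, such as an amine, a carboxylic acid or a longer chain. Such a group on the same carbon of the shared core would show whether this position can move the value beyond the scatter at all.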